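The source may hold more compounds than are shown below. What is called first, only, known or untested is meant among the compounds shown, and "the series" means these compounds.

The account concerns a small set of compounds examined in a functional assay, read by Griess assay, with a stated time of 150 min, tested at 75 ug/mL; on this read-out higher numbers stand for a stronger effect at the one concentration tested and lower numbers for a weaker effect. Compound 1 `O=S(=O)(CC1=NCCS1)c1c(-c2ccccc2)noc1-c1ccccc1` is reported in this assay as "not active" (no number reported). Compound 2 `O=S(=O)(CC1=NCCO1)C1C(c2ccc(Cl)cc2)=NOC1c1ccc(Cl)cc1` is likewise reported in this assay as "not active" (no number reported). Among the measured compounds shown here, compound 3 `COc1ccc(-c2noc(-c3ccc(C)cc3)c2S(=O)(=O)CC2=NCCO2)cc1` gives 73% in this assay, and it is the only member of the set with a numerical read-out.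

Where compound 2 stands, therefore, cannot be fixed on a scale: no single number is attached to it, and compound 1 shares that position, so the set shows one compound with a measured response and two without.

Compound 4 `O=S(=O)(CC1=NCCS1)C1C(c2ccc(Cl)cc2)=NOC1c1ccc(Cl)cc1` has not yet been tested in this assay. It is derived from compound 2 by the change (a group of 5 heavy atoms (3 carbon, 1 nitrogen, 1 sulfur; one five-membered non-aromatic ring with 2 hetero atoms) in place of a group of 5 heavy atoms (3 carbon, 1 nitrogen, 1 oxygen; one five-membered non-aromatic ring with 2 hetero atoms), on a saturated chain carbon bound to a sulfonyl sulfur). No comparison between two measured compounds is available for this exchange, so the size of the step from compound 2 to compound 4 cannot be taken from the data. Compound 1 carries the same group with a sulfur atom in its ring and is reported as not active, which offers no support for a rise. The expectation for compound 4 is thus a weak response, estimated at 15%, with a plausible range from 0% to 45%.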

Compound 4, a percentage reported as activity, at one concentration (the size of the read-out at that concentration, not a potency): "not active" (no number reported)
Compound 4: no number reported, and the estimate cannot be compared.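

Among the compounds shown here, compound 2 and compound 4 both stand without a number in this assay and no step between them can be read. The compounds shown leave open how far this exchange of one five-membered non-aromatic ring for the other would shift a response that gives a number. No evidence on hand bears on this result.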